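Benzyl substitution on the pyrazole nitrogen of the amidine series

The compounds below may be only part of what the source reports. "The series", "measured", "known", "first", "only" and "open" are said of these compounds alone.

Of the compounds shown here, two have been measured in a functional assay on MDA-MB-231 cells (Homo sapiens) for cytotoxicity, read by MTT assay, with a stated time of 72 h; on this read-out lower numbers stand for stronger inhibition and higher numbers for weaker inhibition. Compound 2 `CN1CCN(c2ccc(NC(=N)c3cc4c(-c5ccccc5)n[nH]c4cn3)cc2)CC1` gives 15900 nM and stands at the lower end of the two numbers. Compound 1 `COc1ccc(Cn2nc(-c3ccccc3)c3cc(C(=N)Nc4ccc(N5CCN(C)CC5)cc4)nc(NC4CCCCC4)c32)cc1` differs from compound 2 in two places at once. In this assay compound 1 gives 129000 nM, a gap that lies beyond the usual scatter; with two changes in one step, nothing in the data separates their shares.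

Compound 3 `COc1ccc(Cn2nc(-c3ccccc3)c3cc(C(=N)Nc4ccc(N5CCN(C)CC5)cc4)ncc32)cc1` carries one of those two changes alone, namely (4-methoxybenzyl in place of hydrogen on an aromatic nitrogen). Within the data shown here, no step between measured compounds isolates this change. Among the measured compounds shown here, the only related comparison is compound 1, which carries both changes and whose number sits well above that of compound 2. The expectation is therefore a weakening step of moderate size from compound 2 to compound 3 , estimated as a 2.5-fold higher number from compound 2 to compound 3 (0.40 log units; beyond the scatter), probably smaller than the whole gap from compound 2 to compound 1, since compound 1 carries a further change. The estimate for compound 3 in this assay is 40000 nM, with a range from 12000 nM to 130000 nM.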

Compound 3, half-maximal inhibitory concentration: 1760 nM
Beside the measured number, compound 3's estimate is 23-fold (1.36 log units) above it, outside the stated range (below it).
By their numbers in this assay, from the lowest: compound 3; then compound 2; then compound 1.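

In this assay, 4-methoxybenzyl in place of hydrogen on the aromatic nitrogen is a gain and not a loss, giving a 9.0-fold lower number from compound 2 to compound 3 (0.96 log units; beyond the scatter); the earlier pair, with two changes at once, could not show the direction of this change alone. The second change can now also be read by itself: hydrogen in place of cyclohexylamino on the aromatic carbon gives a 73-fold lower number from compound 1 to compound 3 (1.87 log units; beyond the scatter), so with 4-methoxybenzyl on the nitrogen, cyclohexylamino at this carbon goes with a much higher number. The two single changes therefore run in opposite directions, the first modest and the second large, though each is read on one background only. Nothing shown gives a reason for either step.

On these data alone, it remains open whether the gain at the nitrogen depends on the methoxy group, or whether a plain benzyl or a methyl would give a step of similar size. Also open, as far as these compounds go, is whether a smaller group on the aromatic carbon, such as methylamino, would raise the number as cyclohexylamino does, and whether cyclohexylamino has the same effect when the nitrogen bears hydrogen.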